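A few compounds are considered here, and "the series" means these few. Any claim that something is new, unique, unknown or untested is made for them only; others in the source may bear on it.

In an ADME assay on BJ cells (Homo sapiens) for antiproliferative activity, with a stated time of 72 h (on this read-out lower numbers stand for an effect already at smaller amounts and higher numbers for an effect only at larger amounts of compound), compound 1 `COc1ccc(-c2cc(=O)c3c(OC)cc(OC)cc3n2C)cc1` gives 68000 nM. Compound 2 `COc1ccc(-c2cc(=O)c3c(OC)cc(OC)cc3n2S(=O)(=O)c2ccc([N+](=O)[O-])cc2)cc1` is reported in this assay only as a limit of the assay, > 29300 nM, and so stands at the limit of > 29300 nM in this assay, at which 1 of the 2 values shown sits. Compound 3 `COc1ccc(-c2cc(=O)c3c(OC)cc(OC)cc3n2S(=O)(=O)c2ccc(C)c([N+](=O)[O-])c2)cc1` differs from compound 2 by 4-methyl-3-nitrophenyl in place of 4-nitrophenyl on a sulfonyl sulfur. Among the compounds with values here, no step between measured compounds is available here, and since compound 2 is known only as a limit, nothing beyond the usual scatter is expected in either direction. Compound 3 is expected to give 40000 nM, with a range from 15000 nM to 110000 nM. That estimate corresponds to an expected step that the limit leaves unreadable from compound 2 to compound 3, within the scatter, and most likely again only a limit will be reported.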

Compound 3, half-maximal effective concentration: > 51700 nM
Compound 3 was reported as a limit; the forecaster's own chance of this, stated with the estimate: 70%; middle value at least 1.2-fold (0.11 log units) from the limit.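

Compound 2 and compound 3 are both reported only as limits, and the step between them cannot be read. The compounds shown leave open whether 4-methyl-3-nitrophenyl in place of 4-nitrophenyl changes the result in this assay.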